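Moving the nitrile: compound 2 to compound 4

This account rests on a few compounds, and the source may have more. Where it says the series, first, only, none or still open, it means among the compounds named here.

Going by the values given here, in a functional assay on SH-SY5Y cells (Homo sapiens) for antiproliferative activity, read by MTT assay, with a stated time of 72 h (on this read-out higher numbers stand for weaker inhibition and lower numbers for stronger inhibition), compound 2 `COc1cc2c(Nc3ccc(C#N)cc3)ncnc2cc1OCCCN1CCCCC1` gives 18800 nM, the only actual number so far. Compound 1 `CCN(CC)CCCOc1cc2ncnc(Nc3ccc(C#N)cc3)c2cc1OC` reads > 100000 nM, which is a limit. Compound 3 `COc1cc2c(Nc3ccc(C#N)cc3)ncnc2cc1OCCCN1CCCCC1CCO` reads > 100000 nM, also a limit. Compound 4 `COc1cc2c(Nc3cccc(C#N)c3)ncnc2cc1OCCCN1CCCCC1` has 3-cyanophenyl in place of 4-cyanophenyl on a nitrogen on an aromatic ring. The two readable steps, an at least 5.3-fold lower number from compound 1 to compound 2 (0.72 log units; beyond the scatter) and an at least 5.3-fold higher number from compound 2 to compound 3 (0.72 log units; beyond the scatter), both change the amine on the saturated chain and leave the cyanophenyl untouched. They give no direct size for this change, so no step beyond the scatter is expected, though with wide uncertainty. The expected step is a 1.1-fold higher number from compound 2 to compound 4 (0.03 log units; within the scatter). Compound 4 is estimated at 20000 nM, with an expected range of 6000 nM to 70000 nM.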

Compound 4, half-maximal inhibitory concentration: 11200 nM
Beside the measured number, compound 4's estimate is 1.8-fold (0.25 log units) above it; the range from low to high includes it.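

In this assay, 3-cyanophenyl in place of 4-cyanophenyl gives a 1.7-fold lower number from compound 2 to compound 4 (0.22 log units; within the scatter), so the two groups on this nitrogen cannot be told apart here. Unlike the earlier steps, which changed the amine and each rest on a limit, this step joins two actual numbers and concerns the cyanophenyl itself. Nothing shown bears on why the two placements read alike. Open, as far as these compounds go, is whether a phenyl carrying a carboxylic acid or an amine in place of the nitrile would stay in this range. Also open, from the compounds shown here alone, is whether the same result holds with diethylamino on the chain.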